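The source may report more compounds than this note shows. Statements on the series, on what has been measured and on what is new or still open speak of the compounds shown alone.

Compound 1 `Cc1nc(N)c2c(-c3ccccc3)cn([C@@H]3O[C@H](CO)[C@@H](O)[C@H]3O)c2n1` gives > 20000 nM in a functional assay on HepG2 cells (Homo sapiens) for antiproliferative activity, read by XTT assay, with a stated time of 72 h (a higher number here means a weaker inhibitor, a lower number a stronger inhibitor), which is a limit of the assay and not a number.
Compound 2 `O=c1[nH]cnc2c1c(-c1cc3ccccc3o1)cn2[C@@H]1O[C@H](CO)[C@@H](O)[C@H]1O` gives > 20000 nM in this assay, again only a limit.
Compound 3 `Cc1nc(N)c2c(-c3cc4ccccc4o3)cn([C@@H]3O[C@H](CO)[C@@H](O)[C@H]3O)c2n1` gives > 20000 nM in this assay, again only a limit.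

Compounds 1 and 3 share one core, while compound 2 is built on a different core; the difference between the two cores is not broken down here. From compound 3 to compound 1 the change is phenyl in place of 1-benzofuran-2-yl on an aromatic carbon and the step is a step that the two limits leave unreadable from compound 3 to compound 1. For the measured compounds named here, all three measured values sit at the limit of > 20000 nM in this assay, at which 3 of the 3 values shown sit, so no step between them can be read. Compound 4 `O=c1[nH]cnc2c1c(-c1ccccc1)cn2[C@@H]1O[C@H](CO)[C@@H](O)[C@H]1O` has not yet been measured in this assay. It differs from compound 2 by phenyl in place of 1-benzofuran-2-yl on an aromatic carbon, the same change at the same place as that from compound 3 to compound 1. The expected step from compound 2 to compound 4 in this assay is a step that the limit leaves unreadable from compound 2 to compound 4, and it rests on compound 2 giving only a limit, > 20000 nM, with the earlier step of the same kind also unreadable. Compound 4 is therefore expected to give about 30000 nM in this assay, most likely again reported as a limit, with an expected range from 10000 nM to 100000 nM.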

Compound 4, half-maximal inhibitory concentration: > 20000 nM
Compound 4 ended at the assay's limit (the forecaster's own chance of this, stated with the estimate: 85%); the middle value lies beyond the limit too.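

No step can be read from compound 2 to compound 4, since both results are limits of the assay and not numbers: the limit of > 20000 nM in this assay, at which 4 of the 4 values shown sit.

The compounds shown leave open how far each one lies past that limit in this assay, and so whether phenyl in place of 1-benzofuran-2-yl changes the result at all on either core.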